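Working notes: 2-chlorophenyl to 3-chlorophenyl

The source may report more compounds than this note shows. Statements on the series, on what has been measured and on what is new or still open speak of the compounds shown alone.

Measured in a physicochemical assay for lipophilicity, measured as octanol-water partition; a lower number here means a more polar compound, a higher number a more lipophilic compound:
Compound 1 `O=C(COc1cccc2ccccc12)N/N=C/c1cccc(Br)c1`: 4.81
Compound 2 `O=C(COc1cccc2ccccc12)N/N=C/c1ccccc1Cl`: 4.54

Among the measured compounds shown here, only two values exist so far, and they cannot be separated. For the measured compounds named here, compound 2 stands at 4.54, within the scatter of compound 1, its only measured neighbour.

The next compound to be measured is compound 3 `O=C(COc1cccc2ccccc12)N/N=C/c1cccc(Cl)c1`, which keeps the shared core of compound 2. The structural change is 3-chlorophenyl in place of 2-chlorophenyl on a carbon with a double bond to nitrogen.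

Going by the values given here, only one measured step bears on this change: a number 0.27 log units lower from compound 1 to compound 2 (within the scatter). That step puts 2-chlorophenyl in place of 3-bromophenyl at the same place, so it does not isolate the change at hand. Among the compounds with values here, no measured pair compares 2-chlorophenyl with 3-chlorophenyl directly. Within the data shown here, the one available step stays within the scatter, so no shift beyond the scatter is expected in this assay. The expected step is a number 0.11 log units higher from compound 2 to compound 3 (within the scatter). For compound 3 the estimated value is 4.65, with an expected range from 4.3 to 5.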

Compound 3, partition coefficient: 4.54
Compound 3: the middle estimate sits 0.11 log units above what was measured; the measured number falls inside the stated range.
By their numbers in this assay, from the lowest: compounds 2, 3 and 1 (each within the scatter of the next).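

In this assay, among the compounds shown here, the 3-chlorophenyl group in place of the 2-chlorophenyl group on a carbon with a double bond to nitrogen gives no change at the digits printed from compound 2 to compound 3 (within the scatter) and so provides the first direct comparison of these two groups at this place, which leaves them indistinguishable. Chloro in place of bromo on an aromatic carbon gives a number 0.27 log units lower from compound 1 to compound 3 (within the scatter) and isolates the halogen exchange, which the earlier step between compound 1 and compound 2 could not do because it changed two features of the group at once, and this exchange also stays unresolved. No supporting data bear on these readings.

As far as these compounds go, all three compounds carry a halogen on the phenyl ring, so it remains open whether an amine or a carboxylic acid on that ring would give a step beyond the scatter in this assay. For the compounds shown here, a longer chain in the linker of the shared core is equally open, since every variation so far lies in the chlorophenyl or bromophenyl group alone.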